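A few compounds are considered here, and "the series" means these few. Any claim that something is new, unique, unknown or untested is made for them only; others in the source may bear on it.

Measured so far in an assay on isolated protein with Bile acid receptor (Homo sapiens) as the target; a lower number here means that less compound is needed, a higher number that more compound is needed for the effect:
compound 1, `COC(=O)/C=C/c1cccc(N(Cc2ccc(/C=C/c3ccc(F)cc3)cc2)C(=O)C(C)C)c1`: 120 nM
compound 2, `COC(=O)/C=C/c1cccc(N(Cc2ccc(/C=C/c3ccc(F)cc3)cc2)C(=O)NC(C)C)c1`: 348 nM

For the measured compounds named here, compound 2 carries the higher of the two numbers; its only neighbour is compound 1, from which it is separated by a 2.9-fold higher number from compound 1 to compound 2 (0.46 log units; beyond the scatter), a step that touches the carbonyl substituent alone and leaves the shared core otherwise unchanged.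

Compound 3, `COC(=O)/C=C/c1cccc(N(Cc2ccc(/C=C/C(=O)OC(C)(C)C)cc2)C(=O)NC(C)C)c1`, keeps the urea of compound 2 and changes the far end of the side chain instead: tert-butoxycarbonyl in place of 4-fluorophenyl on a double-bonded chain carbon bound to a double-bonded chain carbon. Going by the values given here, no measured pair covers this exchange or anything resembling it; the single step in hand concerns the carbonyl substituent only and gives no guidance for the group on the double-bonded chain carbon. The direction of the effect is therefore open, and the estimate rests on the value of compound 2 with a wide band around it, leaning toward a higher number on the grounds that an aromatic ring gives way to a chain ester.

Compound 3 is expected to give about 800 nM, within roughly 250 nM to 2500 nM. This estimate amounts to an expected 2.3-fold higher number from compound 2 to compound 3 (0.36 log units; beyond the scatter), with the band wide enough to admit no change beyond the scatter.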

Compound 3, half-maximal effective concentration: 212 nM
The estimate for compound 3 lay 3.8-fold (0.58 log units) above the measured number; measured number below the stated range.
By their numbers in this assay, from the lowest: compounds 1, 3 and 2 (each within the scatter of the next, the first and the last beyond it).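

In this assay, replacing 4-fluorophenyl with tert-butoxycarbonyl on a double-bonded chain carbon bound to a double-bonded chain carbon gives a 1.6-fold lower number from compound 2 to compound 3 (0.22 log units; within the scatter), so with the isopropylamino group on the carbonyl carbon, this position accepts the exchange without a change beyond the scatter. A six-membered aromatic ring at the end of this side chain is therefore not needed to keep the number in the range of compound 2, and a group with no ring and 2 hydrogen-bond acceptors serves there in this single pair. No evidence in hand explains this outcome.

From the compounds shown here alone, it remains open whether the same exchange holds with isopropyl on the carbonyl carbon, as in compound 1, since the side-chain change has been read only with the isopropylamino group in place. Going by these compounds, it is also open whether the result extends to other groups at this position, such as a carboxylic acid, a primary amide or a longer chain ending in an amine, so the present pair marks one tolerated exchange and no general rule for the position.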